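Replacing a chlorophenyl group: effect on liver clearance

The source may report more compounds than this note shows. Statements on the series, on what has been measured and on what is new or still open speak of the compounds shown alone.

Measured compounds:
compound 1, `O=S(=O)(c1ccc(F)c(Cl)c1)c1cnc2cc(F)ccc2c1-c1ccc(Cl)cc1`, 0.39 mL/min
compound 2, `O=S(=O)(c1ccc(F)cc1)c1cnc2cc(F)ccc2c1-c1ccc(Cl)cc1`, 1.23 mL/min
compound 3, `O=S(=O)(c1ccc(F)cc1)c1cnc2cc(Cl)ccc2c1-c1ccc(Cl)cc1`, 0.21 mL/min

In an ADME assay on microsomes from liver (Homo sapiens) for metabolic stability, tested at 2.5 uM (on this read-out higher numbers stand for fast clearance and lower numbers for slow clearance), compound 2 gives the highest of the three numbers, with compound 1 nearest and compound 3 furthest below it. Compound 4, `O=S(=O)(c1ccc(F)cc1)c1cnc2cc(F)ccc2c1-c1cccc(F)c1`, differs from compound 2 by 3-fluorophenyl in place of 4-chlorophenyl on an aromatic carbon. For the measured compounds named here, no measured step touches this group: a 3.2-fold higher number from compound 1 to compound 2 (0.50 log units; beyond the scatter) and a 5.9-fold lower number from compound 2 to compound 3 (0.77 log units; beyond the scatter) both concern other positions, though in the second a chloro in place of a fluoro went with a lower number. With a fluoro entering and a chloro leaving here, the number is expected to stay near compound 2 or rise slightly, a 1.1-fold higher number from compound 2 to compound 4 (0.06 log units; within the scatter). Compound 4 is therefore estimated at 1.4 mL/min, within 0.6 mL/min to 3.2 mL/min.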

Compound 4, intrinsic clearance in a liver preparation (reported as CLH), per the amount of preparation that the assay uses: 0.95 mL/min
The estimate for compound 4 lay 1.5-fold (0.17 log units) above the measured number; the measured number falls inside the stated range.
By their numbers in this assay, from the lowest: compounds 3 and 1 (each within the scatter of the next); then compounds 4 and 2 (each within the scatter of the next).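

At this position, the aromatic carbon opposite the ring nitrogen, this assay now has its first reading: 3-fluorophenyl in place of 4-chlorophenyl gives a 1.3-fold lower number from compound 2 to compound 4 (0.11 log units; within the scatter), so the two groups cannot be told apart here. The earlier steps shown here, at other positions, both lay beyond the scatter. Nothing available explains this result. Going by these compounds, the halogen and its place on the ring change together, so their separate contributions stay unknown. Also open, on these data alone, is how a phenyl ring carrying an amine or a carboxylic acid would behave at this position.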